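The compounds below may be only part of what the source reports. "The series", "measured", "known", "first", "only" and "open" are said of these compounds alone.

Compound 1 `CCS(=O)(=O)Nc1cc(-c2ccc3ncnc(Nc4ccc(OC)cc4)c3c2)cnc1OC`: 3490 nM
Compound 2 `CCCCS(=O)(=O)Nc1cc(-c2ccc3ncnc(Nc4cccc(C(=O)OCC)c4)c3c2)cnc1OC`: 26700 nM

For the measured compounds named here, in a functional assay on HCT-116 cells (Homo sapiens) for cytotoxicity, read by sulforhodamine B assay, with a stated time of 72 h (a higher number here means a weaker inhibitor, a lower number a stronger inhibitor), compound 1 gives 3490 nM, the lowest of the two numbers measured so far, and compound 2 gives 26700 nM, a gap that lies beyond the scatter. Going by the values given here, compound 2 differs from compound 1 in more than one place, so its two values show only that one number is higher than the other. Compound 3 `CCS(=O)(=O)Nc1cc(-c2ccc3ncnc(Nc4ccc(F)nc4)c3c2)cnc1OC` has not yet been measured in this assay. It differs from compound 1 in a single place: 6-fluoropyridin-3-yl in place of 4-methoxyphenyl on a nitrogen on an aromatic ring. Among the compounds with values here, no measured pair shows what this change does, so there is no step to lean on. The expectation is a small shift, if any, toward a higher number, within or close to the scatter, which is an estimated step of a 1.4-fold higher number from compound 1 to compound 3 (0.16 log units; within the scatter). Compound 3 is therefore expected to give about 5000 nM, with a likely range from 1500 nM to 17000 nM.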

Compound 3, half-maximal inhibitory concentration: 7620 nM
The estimate for compound 3 lay 1.5-fold (0.18 log units) below the measured number; low and high end bracket the measured number.
By their numbers in this assay, from the lowest: compound 1; then compound 3; then compound 2.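

In this assay, putting 6-fluoropyridin-3-yl in place of 4-methoxyphenyl on the nitrogen gives a 2.2-fold higher number from compound 1 to compound 3 (0.34 log units; beyond the scatter), the only single-place comparison among the compounds shown. The step is modest but beyond the scatter, so the group at this position does influence the number, and this exchange moves it toward weaker inhibition. No supporting data accompany the step to explain it.

The ring nitrogen and the fluorine enter together, so this one pair cannot show what either contributes alone. As far as these compounds go, it also remains open how the number would respond to a different group on the ring at this position, such as an amine or a carboxylic acid, and whether any such group would move it lower than the value for compound 1.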